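A few compounds are considered here, and "the series" means these few. Any claim that something is new, unique, unknown or untested is made for them only; others in the source may bear on it.

Measured compounds:
compound 1, `O=C(c1ccccc1-c1ccccc1)N1CCCC[C@H]1CCOc1ccc(F)cc1F`, 0.159 nM
compound 2, `O=C(NC[C@@H]1CCCCN1C(=O)c1ccccc1-c1ccccc1)c1ccccc1`, 7.94 nM
compound 3, `O=C(CC[C@@H]1CCCCN1C(=O)c1ccccc1-c1ccccc1)c1ccccc1`, 10 nM

In a functional assay on CHO cells for antagonist activity at Orexin/Hypocretin receptor type 1 (Homo sapiens), read by FLIPR (on this read-out higher numbers stand for weaker inhibition and lower numbers for stronger inhibition), compound 3 gives the highest of the three numbers. Its nearest neighbour is compound 2, a 1.3-fold higher number from compound 2 to compound 3 (0.10 log units; within the scatter), and its furthest is compound 1, a 63-fold higher number from compound 1 to compound 3 (1.80 log units; beyond the scatter). Compound 4, `O=C(NC[C@@H]1CCCCN1C(=O)c1ccccc1-c1ccccc1)Nc1ccccc1`, differs from compound 3 by a single change: (phenylcarbamoyl)amino in place of benzoylmethyl on a saturated chain carbon bound to a saturated ring carbon. Going by the values given here, the step that bears most on this change is the one from compound 2 to compound 3, a 1.3-fold higher number from compound 2 to compound 3 (0.10 log units; within the scatter), where the linker between the chain and the phenyl ring was altered with no movement beyond the scatter. On that basis the step of a 1.3-fold lower number from compound 3 to compound 4 (0.10 log units; within the scatter) is expected to be small. Compound 4 is therefore estimated at 8 nM, with a range from 2.5 nM to 25 nM.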

Compound 4, inhibition constant: 1 nM
Beside the measured number, compound 4's estimate is 8.0-fold (0.90 log units) above it; measured number below the stated range.
By their numbers in this assay, from the lowest: compound 1; then compound 4; then compounds 2 and 3 (each within the scatter of the next).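

In this assay, the group on the saturated chain carbon bound to a saturated ring carbon proves sensitive after all: replacing benzoylmethyl with (phenylcarbamoyl)amino gives a 10-fold lower number from compound 3 to compound 4 (1.00 log units; beyond the scatter), and anilino in place of phenyl on the carbonyl carbon gives a 7.9-fold lower number from compound 2 to compound 4 (0.90 log units; beyond the scatter). The (2,4-difluorophenoxy)methyl group still gives the lowest number, with a 6.3-fold higher number from compound 1 to compound 4 (0.80 log units; beyond the scatter). Nothing available explains these differences. Going by these compounds, it remains open whether the gain depends on the anilino hydrogen, which a methylated anilino nitrogen or a phenoxy group on the same carbonyl would test. On these data alone, whether 2,4-difluoro substitution on the anilino ring would lower the number further is also open.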